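Dropping the aryl methyl of compound 2: an expected loss

This account rests on a few compounds, and the source may have more. Where it says the series, first, only, none or still open, it means among the compounds named here.

Measured so far in an assay on cells for inhibition of sodium/hydrogen exchanger (Oryctolagus cuniculus); a lower number here means a stronger inhibitor, a higher number a weaker inhibitor:
compound 1 `COC1(C)CS(=O)(=O)c2cc(C(=O)N=C(N)N)c(C)cc21` gives 40 nM;
compound 2 `COC1CS(=O)(=O)c2cc(C(=O)N=C(N)N)c(C)cc21` gives 96 nM.

For the measured compounds named here, compound 2 holds the higher of the two numbers, and its only neighbour, compound 1, is below it by a step that lies outside the usual scatter. That step, a 2.4-fold higher number from compound 1 to compound 2 (0.38 log units; beyond the scatter), came from hydrogen in place of methyl on a saturated ring carbon and cost a modest amount of potency.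

Compound 3 `COC1CS(=O)(=O)c2cc(C(=O)N=C(N)N)ccc21` differs from compound 2 by hydrogen in place of methyl on an aromatic carbon. Going by the values given here, no measured pair shows this particular change; the only guide is the methyl removal from compound 1 to compound 2, which weakened the inhibitor modestly. Compound 3 is therefore expected to lose ground by a 2.6-fold higher number from compound 2 to compound 3 (0.42 log units; beyond the scatter), with a direction toward weaker inhibition. The estimate for compound 3 in this assay is 250 nM, within a range of 100 nM to 700 nM.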

Compound 3, half-maximal inhibitory concentration: 700 nM
Compound 3: the middle estimate sits 2.8-fold (0.45 log units) below what was measured; measured number inside the range.
By their numbers in this assay, from the lowest: compound 1; then compound 2; then compound 3.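

In this assay, the aromatic carbon proved more sensitive to losing its methyl than the earlier step had suggested: hydrogen in place of methyl there gave a larger loss (a 7.3-fold higher number from compound 2 to compound 3 (0.86 log units; beyond the scatter)) than the same exchange on the saturated ring carbon (a 2.4-fold higher number from compound 1 to compound 2 (0.38 log units; beyond the scatter)). Across these two steps, removing a methyl weakened the inhibitor at both places, but the size of the loss differed with the place. Nothing available accounts for that difference.

Only hydrogen and methyl appear on that aromatic carbon among the compounds shown, so it stays open whether chlorine, an ethyl group or a methoxy group there would match or surpass methyl. They also leave open whether the two methyl steps would add up in a compound keeping only the saturated-carbon methyl.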